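Compound 2 to compound 4: adding methoxycarbonyl

A few compounds are considered here, and "the series" means these few. Any claim that something is new, unique, unknown or untested is made for them only; others in the source may bear on it.

Compound 1 `CC(Oc1ccc(Oc2ccc(F)cc2)cc1)C(=O)Cn1nnc(-c2ccccc2)n1`, compound 2 `CC(Oc1ccc(Oc2ccc(Cl)cc2)cc1)C(=O)Cn1nnc(-c2ccccc2)n1` and compound 3 `CC(Oc1ccc(Oc2ccc(C(F)(F)F)cc2)cc1)C(=O)Cn1nnc(-c2ccccc2)n1` share one core and differ in a single aromatic substituent. In an ADME assay on S9 fraction from liver (Rattus norvegicus) for metabolic stability, read by LC-MS, using NADPH, with a stated time of 30 min (a higher number here means that more of the compound is left, a lower number that less of the compound is left), compound 2 gives < 5%, which is a limit of the assay and not a number. Compound 1 gives < 5% in this assay, also a limit. Compound 3 gives 6%. The three values thus lie close together, with the limit of < 5% in this assay, at which 2 of the 3 values shown sit.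

The next structure is compound 4 `COC(=O)c1ccc(-c2nnn(CC(=O)C(C)Oc3ccc(Oc4ccc(Cl)cc4)cc3)n2)cc1`, which carries methoxycarbonyl in place of hydrogen on an aromatic carbon, para to a large group (methoxycarbonyl in place of hydrogen on an aromatic carbon). The measured steps bear on this only indirectly, since each exchanges a substituent elsewhere in the molecule. Chloro for fluoro is a step that the two limits leave unreadable from compound 1 to compound 2. Trifluoromethyl for fluoro is a number at least 1 percentage points higher from compound 1 to compound 3 (that floor lies within the scatter), and trifluoromethyl for chloro is a number at least 1 percentage points higher from compound 2 to compound 3 (that floor lies within the scatter). None of these steps is shown to exceed the scatter, and no measured step covers methoxycarbonyl.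

No step beyond the scatter is therefore expected in this assay, in either direction. The expected step is a step that the limit leaves unreadable from compound 2 to compound 4. Among the measured compounds shown here, the expectation also takes in compound 3, whose 6% is the only true number so far. For compound 4 the estimate is 4%, with an expected range from 1% to 11%.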

Compound 4, percent of the compound remaining: < 5%
Compound 4 gave a limit, no number; the forecaster's own chance of this, stated with the estimate: 65%; the middle value lies beyond the limit too.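

In this assay compound 4 gives < 5%, a limit of the assay and not a number. Compound 2 gives < 5%, also a limit, so no step can be read between compound 2 and compound 4. Whether methoxycarbonyl in place of hydrogen changes the percent of compound remaining stays open, as no pair shown has a true number on both sides of that exchange.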